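Compound 1 to compound 4: bromo gives way to methoxy

A few compounds are considered here, and "the series" means these few. Any claim that something is new, unique, unknown or untested is made for them only; others in the source may bear on it.

Measured so far in a physicochemical assay for solubility, in phosphate buffer, measured as kinetic solubility, at pH 7.4 (a lower number here means a less soluble compound, a higher number a more soluble compound), and shown below
- compound 1 (`Cc1oc(-c2c(Cl)cccc2Br)nc1CN1CCC(C(=O)NCCCN2C[C@H](C)C[C@H](C)C2)CC1`) gives (> 83 ug/mL), a limit
- compound 2 (`Cc1cccc(Cl)c1-c1nc(CN2CCC(C(=O)NCCCN3CCCC(C)C3)CC2)c(C)o1`) gives (52.6 ug/mL)
- compound 3 (`Cc1ccccc1-c1nc(CN2CCC(C(=O)N3CCN(CCN(C)C)CC3)CC2)c(C)o1`) gives (> 67 ug/mL), a limit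

Compound 1 stands on a limit (> 83 ug/mL) and not on a number. Compound 4 (`COc1cccc(Cl)c1-c1nc(CN2CCC(C(=O)NCCCN3C[C@H](C)C[C@H](C)C3)CC2)c(C)o1`) is compound 1 with methoxy in place of bromo on an aromatic carbon, turning 2-bromo-6-chlorophenyl into 2-chloro-6-methoxyphenyl. Within the data shown here, no measured pair shows this change. Among the measured compounds shown here, the only exact number comes from compound 2 (52.6 ug/mL), so a modest fall in this assay or none beyond the scatter is expected. The expected step runs (an at least 1.2-fold lower number from compound 1 to compound 4 (0.10 log units; that floor lies within the scatter)) as an estimate. Compound 4 is expected at 65 ug/mL within an estimated range from 38 ug/mL to 85 ug/mL in this measurement.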

Compound 4, solubility: > 76 ug/mL
Compound 4 was reported as a limit; the forecaster's own chance of this, stated with the estimate: 50%; middle value at least 1.1-fold (0.06 log units) away from the limit.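

In this assay compound 1 gives > 83 ug/mL, a limit. Among these compounds, compound 4 gives > 76 ug/mL, also a limit, so no step between these two compounds can be read. From the compounds shown here alone, whether methoxy in place of bromo shifts the result in this assay, and in which direction, stays open.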